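The source may report more compounds than this note shows. Statements on the series, on what has been measured and on what is new or still open speak of the compounds shown alone.

Working notes on the series.

Compound 1 `CCOC(=O)c1cnc(NN2C(=O)C=C(C)C2=O)nc1` carries hydrogen at the aromatic carbon of interest; in a functional assay on Jurkat cells (Homo sapiens) for inhibition (a lower number here means a stronger inhibitor, a higher number a weaker inhibitor), compound 1 gives 13000 nM. Compound 2 `CCOC(=O)c1cnc(NN2C(=O)C=C(C)C2=O)nc1-c1ccco1` places furan-2-yl on that carbon, and in this assay compound 2 gives 1000 nM. Going by the values given here, the one step that can be followed, a 13-fold lower number from compound 1 to compound 2 (1.11 log units; beyond the scatter), is large and beyond the scatter. Among the compounds with values here, compound 2 therefore stands with the lowest number of the two measured compounds, compound 1 being the only neighbour and well separated from it.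

Compound 3 `CCOC(=O)c1cnc(NN2C(=O)C=C(C)C2=O)nc1-c1cc2ccccc2s1` is the next unmeasured member. The change relative to compound 2 is 1-benzothiophen-2-yl in place of furan-2-yl on an aromatic carbon, the position sitting next to the ring nitrogen and ortho to the ethoxycarbonyl group. Within the data shown here, the only step that bears on it is the introduction of an aromatic group at this same carbon, a 13-fold lower number from compound 1 to compound 2 (1.11 log units; beyond the scatter), which shows the position tolerates and rewards an aromatic substituent. Among the measured compounds shown here, no measured pair shows one aromatic group exchanged for another here, so the size of the effect of enlarging the group is not known from the data. A step of modest size is expected, a 1.7-fold lower number from compound 2 to compound 3 (0.22 log units; within the scatter), leaning toward a lower number. Compound 3 is estimated at 600 nM in this assay, with a range from 150 nM to 2500 nM.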

Compound 3, half-maximal inhibitory concentration: 800 nM
For compound 3 the middle estimate is 1.3-fold (0.12 log units) below the measured one; the measured number falls inside the stated range.
By their numbers in this assay, from the lowest: compounds 3 and 2 (each within the scatter of the next); then compound 1.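

In this assay, replacing furan-2-yl with 1-benzothiophen-2-yl on this carbon gives a 1.3-fold lower number from compound 2 to compound 3 (0.10 log units; within the scatter) and so leaves the number within the scatter, even with the added six-membered aromatic ring of carbon only and sulfur in place of oxygen as the ring hetero atom. The advantage over hydrogen is therefore not confined to furan-2-yl: the second aromatic group gives a 16-fold lower number from compound 1 to compound 3 (1.21 log units; beyond the scatter) and, like the first, stands well apart from the unsubstituted compound. No measurement available here accounts for the two aromatic groups reading alike.

The compounds shown leave open whether the effect at this carbon needs an aromatic ring at all, which a methyl group, a longer alkyl chain or a primary amine in the same place would test, and whether a six-membered ring such as phenyl or pyridin-2-yl reads like these two five-membered attachments. The separate contributions of the fused benzene ring and the sulfur also remain unresolved, and thiophen-2-yl and 1-benzofuran-2-yl are the groups that would divide them.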